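The compounds below may be only part of what the source reports. "The series", "measured", "known", "first", "only" and "open" are said of these compounds alone.

Compound 1: `O=C(Nc1ccc(S(=O)(=O)C(F)(F)F)cc1)C1=CCN(c2ncccc2Cl)CC1` gives 41 nM
Compound 2: `O=C(Nc1ccc(Cl)cc1)C1=CCN(c2ncccc2Cl)CC1` gives 33 nM

Among the compounds with values here, in an in vitro functional assay on 1321-N1 cells for antagonist activity at transient receptor potential cation channel subfamily V member 1 (Homo sapiens), read by FLIPR and calcium flux (on this read-out lower numbers stand for stronger inhibition and higher numbers for weaker inhibition), compound 2 and compound 1 sit within the scatter of each other, as the only measured step, a 1.2-fold lower number from compound 1 to compound 2 (0.09 log units; within the scatter), shows. Compound 3, `O=C(Nc1ccc(Cl)c(F)c1)C1=CCN(c2ncccc2Cl)CC1`, differs from compound 2 by fluoro in place of hydrogen on an aromatic carbon. Within the data shown here, no measured step touches this position, and the one step known changes a group elsewhere on the same ring without moving beyond the scatter. An added fluoro of this kind is expected to leave the number roughly where it is, so the estimated step is a 1.1-fold lower number from compound 2 to compound 3 (0.04 log units; within the scatter). Compound 3 is therefore expected at about 30 nM, within a range from 12 nM to 75 nM.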

Compound 3, half-maximal inhibitory concentration: 78 nM
Compound 3: the middle estimate sits 2.6-fold (0.41 log units) below what was measured; the measured number lies above the stated range.
By their numbers in this assay, from the lowest: compounds 2, 1 and 3 (each within the scatter of the next, the first and the last beyond it).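

Placing fluoro on the aromatic carbon ortho to the chloro group gives a 2.4-fold higher number from compound 2 to compound 3 (0.37 log units; beyond the scatter) in this assay, a modest step but one beyond the scatter. This shows that the number responds to a single added atom at this position, whereas the earlier swap of (trifluoromethyl)sulfonyl for chloro stayed within the scatter. Nothing available explains this weakening.

On these data alone, whether a methyl, a methoxy or an amine at this same position would weaken inhibition further remains open. It is also unknown whether fluoro has the same effect without the chloro group.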